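Chloro-to-hydrogen step on the pendant aryl ring

The compounds below may be only part of what the source reports. "The series", "measured", "known", "first", "only" and "open" are said of these compounds alone.

Measured compounds:
- compound 1 `O=C(Nc1ccc(-n2ccc3c(NC(=O)c4ccccc4)ncnc32)cc1)Nc1ccc(Cl)c(C(F)(F)F)c1`: 6000 nM
- compound 2 `Nc1ncnc2c1ccn2-c1ccc(NC(=O)c2ccc(Cl)c(C(F)(F)F)c2)cc1`: 5600 nM
- compound 3 `O=C(Nc1ccc(-n2ccc3c(NC(=O)c4ccccc4)ncnc32)cc1)Nc1cccc(C(F)(F)F)c1`: 4500 nM

All three were run in an ADME assay on HS27 cells (Homo sapiens) for antiproliferative activity, read by MTT assay, with a stated time of 24 h; a higher number here means a weaker inhibitor, a lower number a stronger inhibitor. Compound 1 and compound 3 share one core; compound 2 carries a different core, and the difference between the two cores is not broken down here. In this assay the three values sit close together: compound 1 gives 6000 nM, compound 2 gives 5600 nM, and compound 3 gives 4500 nM.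

For the measured compounds named here, the one step that is counted here is hydrogen in place of chloro on an aromatic carbon, and it made a 1.3-fold lower number from compound 1 to compound 3 (0.12 log units; within the scatter).

Compound 4 `Nc1ncnc2c1ccn2-c1ccc(NC(=O)c2cccc(C(F)(F)F)c2)cc1` is not yet measured. It differs from compound 2 by hydrogen in place of chloro on an aromatic carbon, the same change that compound 1 to compound 3 shows, at a place described in identical words. On that basis the step is expected to be small: a 1.2-fold lower number from compound 2 to compound 4 (0.07 log units; within the scatter), resting on a 1.3-fold lower number from compound 1 to compound 3 (0.12 log units; within the scatter). Compound 4 is therefore estimated at 4800 nM in this assay, with a range from 2400 nM to 9600 nM.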

Compound 4, half-maximal inhibitory concentration: 7100 nM
The estimate for compound 4 lay 1.5-fold (0.17 log units) below the measured number; low and high end bracket the measured number.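

In this assay, hydrogen in place of chloro, ortho to a trifluoromethyl group, gives a 1.3-fold higher number from compound 2 to compound 4 (0.10 log units; within the scatter) on the second core, a step too small to read as an effect. Set beside the earlier step, the two results agree within what the measurements can resolve: the same change on two cores in this assay, a 1.3-fold lower number (0.12 log units; within the scatter) from compound 1 to compound 3 and a 1.3-fold higher number (0.10 log units; within the scatter) from compound 2 to compound 4, 1.7-fold (0.23 log units) apart, within the scatter of two such steps. In this series the change therefore carries from one core to the other as a step within the scatter on both, but the differing signs of the two steps carry no weight, and two pairs in one cell assay do not show that the cores respond alike to a change that has a larger effect.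

From the compounds shown here alone, all four compounds keep the trifluoromethyl group, so what happens when it gives way to a methyl group, a nitrile or an amine remains open. Also open, going by these compounds, is whether a bromo, methyl or methoxy group in the chloro position would give a step beyond the scatter on either core.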